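This account rests on a few compounds, and the source may have more. Where it says the series, first, only, none or still open, it means among the compounds named here.

Measured in a functional assay on HCT-8 cells (Homo sapiens) for cytotoxicity; on this read-out higher numbers stand for an effect only at larger amounts of compound and lower numbers for an effect already at smaller amounts:
compound 1 `c1ccc(COc2cc(-c3ccccc3)nc3ccccc23)cc1`: > 10 ug/mL (a limit)
compound 2 `CC(C)Oc1cc(-c2ccccc2)nc2ccccc12`: 10 ug/mL
compound 3 `CCCCOc1cc(-c2ccccc2)nc2ccccc12`: > 10 ug/mL (a limit)

In this series, compound 3 stands at > 10 ug/mL, which is a limit and not a number. The same holds for most of the series, as the data show (the limit of > 10 ug/mL in this assay, at which 2 of the 3 values shown sit).

The next change leads to compound 4 `CC(C)COc1cc(-c2ccccc2)nc2ccccc12`: isopropyl in place of propyl on a saturated chain carbon bound to an oxygen on an aromatic ring. This is butoxy to isobutoxy on the shared core.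

Among the compounds with values here, two measured steps bear on it. These are a number no lower from compound 2 to compound 3 (the limit leaves the size open) and a number no higher from compound 1 to compound 2 (the limit leaves the size open), and neither size can be read. Within the data shown here, the only number is that of compound 2, at 10 ug/mL, so the expectation rests on it. In this assay, a step no higher is expected, and a result at the limit remains quite likely. The expected step is an at least 1.2-fold lower number from compound 3 to compound 4 (0.09 log units; that floor lies within the scatter), its true size left open by the limit on the starting value. For compound 4 the estimated value is 8 ug/mL, with an expected range from 3 ug/mL to 12 ug/mL.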

Compound 4, half-maximal effective concentration: > 10 ug/mL
Compound 4 gave a limit, no number; the forecaster's own chance of this, stated with the estimate: 55%; middle value at least 1.2-fold (0.09 log units) away from the limit.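

In this assay compound 4 gives > 10 ug/mL, which is a limit and not a number, so moving from butoxy to isobutoxy on the shared core does not yield a readable value. The steps linking compound 4 to compound 3 and to compound 1 cannot be read, so no size can be given for this change. The only step with a readable direction is a number no lower from compound 2 to compound 4 (the limit leaves the size open), and compound 2 remains the only compound with a number: the limit of > 10 ug/mL in this assay, at which 3 of the 4 values shown sit.

On these data alone, how far the compounds at the limit lie from compound 2 remains open. Also open, as far as these compounds go, is whether a methyl group, or a longer chain carrying an amine or a carboxylic acid, on an oxygen on an aromatic ring gives a number in this assay.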